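Chain extension carried from one core to another

The compounds below may be only part of what the source reports. "The series", "measured", "known", "first", "only" and "open" are said of these compounds alone.

Compound 2 `CCCC(=O)c1c(O)c(Cl)c(O)c(Cl)c1O` and compound 1 `CCCCCC(=O)c1c(O)c(Cl)c(O)c(Cl)c1O` share one core and differ in a single place: ethyl in place of hydrogen on a saturated chain carbon, three bonds along the chain from a carbonyl carbon. In a functional assay on the whole organism (S2 cells, strain S2) for inhibition, with Drosophila as the target, read by a luciferase reporter, with stated times of 1.5 h and 8 h (a lower number here means a stronger inhibitor, a higher number a weaker inhibitor), compound 2 gives 21500 nM, while compound 1 gives 9900 nM, a step of a 2.2-fold lower number from compound 2 to compound 1 (0.34 log units; beyond the scatter). Compound 3 `CCCCC(=O)c1c(OC)c(Cl)c(OC)c(Cl)c1OC` sits on a different core; the difference between the two cores is not broken down here. In this assay compound 3 gives 23500 nM, the highest number of the three, close to compound 2 and further from compound 1. Compound 4 `CCCCCCC(=O)c1c(OC)c(Cl)c(OC)c(Cl)c1OC` is not yet measured. It differs from compound 3 by ethyl in place of hydrogen on a saturated chain carbon, four bonds along the chain from a carbonyl carbon, the same kind of change as that from compound 2 to compound 1 but not the same, since here the carbon that takes the ethyl lies four bonds along the chain from the carbonyl carbon rather than three. Compound 4 is expected at about 13000 nM, with a range from 6000 nM to 26000 nM. The estimated step of a 1.8-fold lower number from compound 3 to compound 4 (0.26 log units; within the scatter) is set somewhat smaller than the measured one because a 2.2-fold lower number from compound 2 to compound 1 (0.34 log units; beyond the scatter) was obtained on the core of compound 1, and no change on the core of compound 3 has yet been measured.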

Compound 4, half-maximal inhibitory concentration: 16800 nM
The estimate for compound 4 lay 1.3-fold (0.11 log units) below the measured number, and the stated range covers the measured number.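

In this assay, ethyl in place of hydrogen on the core of compound 3 gives a 1.4-fold lower number from compound 3 to compound 4 (0.15 log units; within the scatter), a step that alone cannot be told apart from repeat scatter. Set beside the step on the core of compound 1, it shows no measurable difference between the two cores, so the results fit a change that carries over, though only modestly: the same change on two cores in this assay, a 2.2-fold lower number (0.34 log units; beyond the scatter) from compound 2 to compound 1 and a 1.4-fold lower number (0.15 log units; within the scatter) from compound 3 to compound 4, 1.6-fold (0.19 log units) apart, within the scatter of two such steps. For the compounds shown here, this does not establish transfer, since it rests on two pairs, only one step lies beyond the scatter, and the carbon taking the ethyl sits three bonds along the chain from the carbonyl carbon in one pair and four in the other.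

The compounds shown leave the contribution of the core unseparated from that of chain length, as no chain appears on both cores. Also open, from the compounds shown here alone, is how either core would respond to a longer chain, or to an amine or a carboxylic acid on the chain.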